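This account rests on a few compounds, and the source may have more. Where it says the series, first, only, none or still open, it means among the compounds named here.

Working notes on the series. Of the compounds shown here, two have been measured in an in vitro functional assay on 1321-N1 cells for agonist activity at Free fatty acid receptor 1 (Homo sapiens), read by fluorescence; on this read-out lower numbers stand for an effect already at smaller amounts and higher numbers for an effect only at larger amounts of compound. Compound 1 `O=Cc1cccc(C#Cc2ccc(CCC(=O)O)cc2)c1` gives 355 nM in this assay. Compound 2 `Cc1cccc(C#Cc2ccc(CCC(=O)O)cc2)c1C` gives 87.1 nM in this assay, the lower of the two numbers; the gap to compound 1 is beyond the scatter, so compound 2 stands as the stronger of the pair on the numbers shown.

The next compound, compound 3 `Cc1cccc(C#Cc2ccc(CCC(=O)O)cc2)c1`, has not yet been measured. It differs from compound 2 in one place: hydrogen in place of methyl on an aromatic carbon. Going by the values given here, no step between measured compounds matches this change, so there is no direct precedent. The expectation is a step of modest size, toward a higher number, in this assay, since compound 2 with 87.1 nM carries the lower number of the two known points and compound 3 loses one of its methyl groups. For compound 3 the estimate in this assay is 160 nM, with a range from 60 nM to 420 nM; this corresponds to an expected step of a 1.8-fold higher number from compound 2 to compound 3 (0.26 log units; within the scatter).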

Compound 3, half-maximal effective concentration: 43.7 nM
The estimate for compound 3 lay 3.7-fold (0.56 log units) above the measured number; the whole stated range lies above it.
By their numbers in this assay, from the lowest: compounds 3 and 2 (each within the scatter of the next); then compound 1.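

Read in this assay the swap of hydrogen for methyl on the aromatic carbon ortho to a large group gives a 2.0-fold lower number from compound 2 to compound 3 (0.30 log units; within the scatter) and so shows that compound 3 stays within the scatter of compound 2 without this methyl. At the aromatic carbon where compound 1 carries formyl, methyl in place of formyl gives an 8.1-fold lower number from compound 1 to compound 3 (0.91 log units; beyond the scatter) and so shows that the group at this carbon matters to the number, which compounds 1 and 2 alone, differing in more than one place, could not show. Nothing at hand bears on the reason for either step.

Open, on these data alone, is how an amine, a hydroxyl or a longer chain such as ethyl would read in place of the remaining methyl. Also open, as far as these compounds go, is where hydrogen at that same carbon would fall.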